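Giving up the 2,5-dimethylphenyl group in the sulfonamide series

A few compounds are considered here, and "the series" means these few. Any claim that something is new, unique, unknown or untested is made for them only; others in the source may bear on it.

In a functional assay on HT-1080 cells (Homo sapiens) for antiproliferative activity, read by sulforhodamine B assay, with a stated time of 48 h (a lower number here means a stronger inhibitor, a higher number a weaker inhibitor), compound 1 `Cc1cccc(NS(=O)(=O)c2ccc(N3CCNC3=O)cc2)c1` gives 210 nM and compound 2 `Cc1ccc(C)c(NS(=O)(=O)c2ccc(N3CCNC3=O)cc2)c1` gives 65 nM. For the measured compounds named here, compound 2 therefore holds the lower of the two numbers so far, and the gap to compound 1 lies beyond the scatter.

The next entry is compound 3 `O=C1NCCN1c1ccc(S(=O)(=O)Nc2cccc(Cl)c2)cc1`, which has not yet been measured. It has 3-chlorophenyl in place of 2,5-dimethylphenyl on a sulfonamide nitrogen.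

Going by the values given here, only one measured step bears on this change: a 3.2-fold lower number from compound 1 to compound 2 (0.51 log units; beyond the scatter), a modest step with methyl in place of hydrogen on an aromatic carbon. Among the compounds with values here, no measured step covers chlorine, so that part of the change has no direct support in the data. Compound 3 gives up the 2,5-dimethylphenyl group of compound 2, so a step of similar size to a 3.2-fold lower number from compound 1 to compound 2 (0.51 log units; beyond the scatter) is expected in this assay, towards a higher number and probably beyond the scatter. The estimated step is a 3.1-fold higher number from compound 2 to compound 3 (0.49 log units; beyond the scatter). Compound 3 is expected at 200 nM, with an estimated range of 70 nM to 600 nM.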

Compound 3, half-maximal inhibitory concentration: 68 nM
For compound 3 the middle estimate is 2.9-fold (0.47 log units) above the measured one; the whole stated range lies above it.
By their numbers in this assay, from the lowest: compounds 2 and 3 (each within the scatter of the next); then compound 1.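

In this assay, 3-chlorophenyl can stand in place of 2,5-dimethylphenyl on the sulfonamide nitrogen without leaving the scatter: a 1.0-fold higher number from compound 2 to compound 3 (0.02 log units; within the scatter). The substituent on this aromatic ring can therefore be changed in more than one way and still separate a compound from compound 1, as chloro in place of methyl on an aromatic carbon gives a 3.1-fold lower number from compound 1 to compound 3 (0.49 log units; beyond the scatter), while the added methyl gave a 3.2-fold lower number from compound 1 to compound 2 (0.51 log units; beyond the scatter). For the compounds shown here, the series so far thus offers two distinct aryl groups, 2,5-dimethylphenyl and 3-chlorophenyl, that cannot be told apart in this read-out, and no measurement at hand offers an explanation for this equivalence.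

The compounds shown leave open whether a second chlorine on the ring, as in a dichlorophenyl group, would take the number beyond that of compound 3, and whether a ring bearing a methoxy group, an amine or a carboxylic acid would hold it. They also leave open how far the shared core tolerates change, as all three compounds carry it unaltered.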